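The source may hold more compounds than are shown below. What is called first, only, known or untested is meant among the compounds shown, and "the series" means these compounds.

Measured in a functional assay on HT-29 cells (Homo sapiens) for inhibition, read by sulforhodamine B assay, with a stated time of 48 h; a lower number here means a stronger inhibitor of growth, a higher number a weaker inhibitor of growth:
compound 1 `c1cc(C2CCCCC2)ccc1NC1=NCCO1`: 12800 nM
compound 2 `c1ccc(-c2ccc(NC3=NCCO3)cc2)cc1`: 5800 nM
compound 3 `CC(C)(C)c1ccc(NC2=NCCO2)cc1`: 1500 nM

Compound 3 gives the lowest number of the three, and both steps that reach it lie beyond the scatter: an 8.5-fold lower number from compound 1 to compound 3 (0.93 log units; beyond the scatter) and a 3.9-fold lower number from compound 2 to compound 3 (0.59 log units; beyond the scatter). The remaining measured step is a 2.2-fold lower number from compound 1 to compound 2 (0.34 log units; beyond the scatter).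

The next compound is compound 4 `Cc1ccc(NC2=NCCO2)cc1`. The change is methyl in place of tert-butyl on an aromatic carbon. Among the compounds with values here, no measured compound carries methyl, so the three steps bear on this change only indirectly. All three are modest, and the cyclohexyl and phenyl compounds both stand higher than compound 3. Three compounds cannot fix a direction firmly, but leaving tert-butyl is expected to raise the number by a similarly modest amount, and a wide range is warranted.

In this assay the expected change is a 4.0-fold higher number from compound 3 to compound 4 (0.60 log units; beyond the scatter). The estimated value for compound 4 is 6000 nM, with an expected range of 1800 nM to 22000 nM.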

Compound 4, concentration for 50% growth inhibition: 13000 nM
Compound 4: middle estimate off by 2.2-fold (0.34 log units), on the low side, within the range that was stated.
By their numbers in this assay, from the lowest: compound 3; then compound 2; then compounds 1 and 4 (each within the scatter of the next).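

In this assay, methyl in place of tert-butyl gives an 8.7-fold higher number from compound 3 to compound 4 (0.94 log units; beyond the scatter), so among the four groups at this position the lowest number belongs to tert-butyl alone and does not extend to the smaller alkyl group. Methyl also stands apart from phenyl, with a 2.2-fold higher number from compound 2 to compound 4 (0.35 log units; beyond the scatter), but cannot be separated from cyclohexyl, with a 1.0-fold higher number from compound 1 to compound 4 (0.01 log units; within the scatter), so the number does not move in one direction with group size: tert-butyl, phenyl and cyclohexyl go against any such trend. No measured property accompanies these compounds to account for this pattern.

As far as these compounds go, whether the low number depends on the branched shape of tert-butyl remains open, and ethyl, isopropyl or a longer chain would test this. From the compounds shown here alone, how an amine or a carboxylic acid would read at this place is also open.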